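Swapping the ring amine on a four-carbon chain

The compounds below may be only part of what the source reports. "The series", "measured", "known", "first", "only" and "open" are said of these compounds alone.

Compound 1: `CN1CCN(CCCCOc2c(O)cc3oc(-c4ccccc4)cc(=O)c3c2O)CC1` — 93700 nM
Compound 2: `CCN(CC)CCCOc1c(OC)cc2oc(-c3ccccc3)cc(=O)c2c1O` — 3700 nM
Compound 3: `COc1cc2oc(-c3ccccc3)cc(=O)c2c(O)c1OCCCCN1CCN(C)CC1` — 36700 nM

These three compounds share one core and differ only in the side chain that hangs from an oxygen on the aromatic ring and in whether a neighbouring oxygen carries a methyl or a hydrogen. In a functional assay on HepG2 cells (Homo sapiens) for antiproliferative activity, read by MTT assay, with a stated time of 48 h (on this read-out lower numbers stand for stronger inhibition and higher numbers for weaker inhibition), compound 3 stands second highest of the three numbers: compound 1 lies nearest, and compound 2 furthest, as the steps of a 2.6-fold lower number from compound 1 to compound 3 (0.41 log units; beyond the scatter) and a 9.9-fold higher number from compound 2 to compound 3 (1.00 log units; beyond the scatter) show.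

Compound 4 is `COc1cc2oc(-c3ccccc3)cc(=O)c2c(O)c1OCCCCN1CCCCC1`. It differs from compound 3 in one place: piperidin-1-yl in place of 4-methylpiperazin-1-yl on a saturated chain carbon, four bonds along the chain from an oxygen on an aromatic ring. The step that bears on this is a 9.9-fold higher number from compound 2 to compound 3 (1.00 log units; beyond the scatter), where a chain ending in a single basic nitrogen was replaced by the methylpiperazinyl group and the number rose. Piperidin-1-yl again carries one nitrogen, so the move back toward such an amine is expected to lower the number, though not fully to the level of compound 2, since the chain length also differs. The expected step is a 4.1-fold lower number from compound 3 to compound 4 (0.61 log units; beyond the scatter). Compound 4 is therefore estimated at 9000 nM, between 3000 nM and 27000 nM.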

Compound 4, half-maximal inhibitory concentration: 21000 nM
The estimate for compound 4 lay 2.3-fold (0.37 log units) below the measured number, within the range that was stated.
By their numbers in this assay, from the lowest: compound 2; then compounds 4 and 3 (each within the scatter of the next); then compound 1.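

At this position, on a saturated chain carbon, four bonds along the chain from an oxygen on an aromatic ring, piperidin-1-yl in place of 4-methylpiperazin-1-yl gives a 1.7-fold lower number from compound 3 to compound 4 (0.24 log units; within the scatter) in this assay, so these two ring amines cannot be told apart here, although the entering group has one nitrogen and the leaving group two. Set against diethylamino, the piperidine side chain shows a 5.7-fold higher number from compound 2 to compound 4 (0.75 log units; beyond the scatter), so the second ring nitrogen alone does not account for a 9.9-fold higher number from compound 2 to compound 3 (1.00 log units; beyond the scatter). No other measurement bears on this result, and the data offer no explanation for it.

From the compounds shown here alone, compound 2 differs from compound 4 in both its amine and its chain length, so the share of each remains open. Also open, going by these compounds, is how a morpholine ring at the same chain end, or a longer chain, would read in this assay.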